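Adding a Methoxy Group to a Dienone

The source may hold more compounds than are shown below. What is called first, only, known or untested is meant among the compounds shown, and "the series" means these compounds.

The study concerns two measured compounds and one that awaits measurement. Compound 1 `COc1ccc(/C=C/C(O)=C/C(=O)c2c(O)cccc2OC)cc1OC` and compound 2 `COc1ccc(/C=C/C=C/C(=O)c2ccccc2O)cc1OC` were both tested in an in vitro assay on cells for inhibition of Amine oxidase [flavin-containing] A (Homo sapiens), read by Amplex Red, with a stated time of 15 min, tested at 100 uM; a lower number here means less inhibition, a higher number more inhibition at the concentration tested (going by the name of the read-out). In this assay compound 1 gives 40%, and compound 2 gives 40%, so compound 2 stands level with compound 1 at the digits reported, with no change beyond the scatter between the two.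

Compound 3 `COc1ccc(/C=C/C=C/C(=O)c2c(O)cccc2OC)cc1OC` is the next compound and differs from compound 2 in one place: methoxy in place of hydrogen on an aromatic carbon. Among the compounds with values here, no step between measured compounds is available to calibrate this change, so the expectation for compound 3 rests on the two values alone. Since compound 1 already carries this group and matches compound 2, the step expected from compound 2 to compound 3 is no change at the digits printed from compound 2 to compound 3 (within the scatter), which amounts to none beyond the scatter. The estimate for compound 3 in this assay is therefore 40%, with a range from 25% to 55%.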

Compound 3, a percentage reported as inhibition, at one concentration (the size of the read-out at that concentration, not a potency): 40%
Compound 3: middle estimate and measured number agree at the digits printed; measured number inside the range.
By their numbers in this assay, from the lowest: compounds 1, 2 and 3 (each within the scatter of the next).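

In this assay, methoxy in place of hydrogen on an aromatic carbon, ortho to a large group and meta to a hydroxy group, gives no change at the digits printed from compound 2 to compound 3 (within the scatter) and so leaves the reading level at this position. The other newly available step, hydrogen in place of hydroxy on a double-bonded chain carbon bound to two double-bonded chain carbons, gives no change at the digits printed from compound 1 to compound 3 (within the scatter) and so shows that the chain position, too, can be changed with the reading staying level. No supporting measurement bears on why these readings stay level. Going by these compounds, whether an amine or a carboxylic acid on the same aromatic carbon would also leave the reading level remains open. A reading at one concentration also leaves open whether the potencies of these compounds differ.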